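Acetamido for methyl on the aryl ring of compound 3

The source may report more compounds than this note shows. Statements on the series, on what has been measured and on what is new or still open speak of the compounds shown alone.

compound 3: `C=CC[C@H]1C[C@]2([C@@H](C)Cc3ccc(OC)c(C)c3)OCOC2=CC1=O` — 410 nM
compound 1: `C=CC[C@@H]1C[C@]2([C@@H](C)Cc3ccc(OC)c(OC)c3)OCOC2=CC1=O` — > 4000 nM
compound 2: `C=CC[C@H]1C[C@]2([C@@H](C)Cc3ccc(O)cc3)OCOC2=CC1=O` — > 20000 nM

For the measured compounds named here, in a functional assay on M14 cells (Homo sapiens) for antiproliferative activity, with a stated time of 72 h (on this read-out lower numbers stand for stronger inhibition and higher numbers for weaker inhibition), compound 3 gives 410 nM, the only number among the three values shown. For compound 1 the value > 4000 nM is a limit of the assay and not a number. For compound 2 the value > 20000 nM is likewise a limit. Going by the values given here, compound 1 and compound 2 differ from compound 3 in more than one place, so their values show only that compound 3 is the one compound of the three with a measured number, the other two resting at the limit of > 4000 nM in this assay, at which 1 of the 3 values shown sits, and (the limit of > 20000 nM in this assay, at which 1 of the 3 values shown sits).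

Compound 4, `C=CC[C@H]1C[C@]2([C@@H](C)Cc3ccc(OC)c(NC(C)=O)c3)OCOC2=CC1=O`, differs from compound 3 in one place: acetamido in place of methyl on an aromatic carbon. Among the compounds with values here, no single step between measured compounds is available in this assay, so the expectation rests on the structural change alone. A loss beyond the usual scatter is expected, in the direction of weaker inhibition; the step from compound 3 to compound 4 is estimated at a 7.3-fold higher number from compound 3 to compound 4 (0.86 log units; beyond the scatter). Compound 4 is therefore expected to give about 3000 nM in this assay, with a range from 800 nM to 15000 nM.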

Compound 4, half-maximal inhibitory concentration: 85 nM
The estimate for compound 4 lay 35-fold (1.55 log units) above the measured number, and the stated range ends above it.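

In this assay, the aromatic carbon ortho to a methoxy group accepts acetamido in place of methyl with a gain, not a loss: a 4.8-fold lower number from compound 3 to compound 4 (0.68 log units; beyond the scatter). This is the first comparison among these compounds that changes a single place, and it shows that a group of 4 heavy atoms, carrying a hydrogen-bond donor and a hydrogen-bond acceptor, can stand here without weakening inhibition. Nothing measured for these compounds gives a cause for the gain.

The compounds shown leave open whether the acetamido group acts through the amide hydrogen, the carbonyl or its size, which a free amine, an N-methyl acetamide or a propionamide at this carbon could help to separate. Also open, on these data alone, is how the ring would respond to a carboxylic acid or a longer acyl chain here.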